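The compounds below may be only part of what the source reports. "The series", "measured", "known", "first", "only" and "open" are said of these compounds alone.

Measured compounds:
Compound 1, `CC1(CC#Cc2c(Cl)c3c(Cl)cc(C(N)=O)nc3n2[C@H]2CCCNC2)COC1`: in a functional assay on KG-1 cells (Homo sapiens) for antiproliferative activity (a higher number here means that more compound is needed for the effect, a lower number that less compound is needed), compound 1 gives 289 nM.
Compound 2, `CN1CC(C#Cc2c(Cl)c3c(Cl)cc(C(N)=O)nc3n2[C@H]2CCCNC2)CC1=O`: compound 2 gives 155 nM.
Compound 3, `COCCC#Cc1c(Cl)c2c(Cl)cc(C(N)=O)nc2n1[C@H]1CCCNC1`: compound 3 gives 39 nM.

Compound 3 has the lowest number of the three, and both steps leading to it lie beyond the scatter, so it stands apart. Compound 4, `CC(C)(O)C#Cc1c(Cl)c2c(Cl)cc(C(N)=O)nc2n1[C@H]1CCCNC1`, differs from compound 3 by 1-hydroxy-1-methylethyl in place of 2-methoxyethyl on a triple-bonded carbon. The two steps that bear on this change, a 7.4-fold lower number from compound 1 to compound 3 (0.87 log units; beyond the scatter) and a 4.0-fold lower number from compound 2 to compound 3 (0.60 log units; beyond the scatter), show that the short chain without a ring gave lower numbers than the ring-bearing groups, and compound 4 keeps a short group without a ring. Going by the values given here, no measured step tells what the added hydroxyl donor does. Compound 4 is therefore expected to show the step of a 1.3-fold higher number from compound 3 to compound 4 (0.11 log units; within the scatter), and its estimated value is 50 nM, in a range from 20 nM to 150 nM.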

Compound 4, half-maximal effective concentration: 302 nM
For compound 4 the middle estimate is 6.0-fold (0.78 log units) below the measured one; the whole stated range lies below it.
By their numbers in this assay, from the lowest: compound 3; then compounds 2, 1 and 4 (each within the scatter of the next).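

In this assay the step of a 7.7-fold higher number from compound 3 to compound 4 (0.89 log units; beyond the scatter) shows that this place on the triple-bonded carbon separates two groups with the same heavy atoms, so the atom count alone does not settle the result. Having no ring is not enough either: a 1.9-fold higher number from compound 2 to compound 4 (0.29 log units; within the scatter) and a 1.0-fold higher number from compound 1 to compound 4 (0.02 log units; within the scatter) both stay within the scatter. Nothing shown here explains the gap between 2-methoxyethyl and 1-hydroxy-1-methylethyl.

Whether the hydroxyl or the branched carbon accounts for the step stays open. Comparing 2-hydroxyethyl and 1-methoxy-1-methylethyl at this place could separate the two.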